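Weak Cytotoxicity Series: From Compound 3 to Compound 4

A few compounds are considered here, and "the series" means these few. Any claim that something is new, unique, unknown or untested is made for them only; others in the source may bear on it.

Compound 1 `Cc1ccc(N2C(=O)C/C(=C\c3cccc(C(=O)Nc4cccc(F)c4)c3)C2=O)cc1`: in an ADME assay on SW480 cells (Homo sapiens) for cytotoxicity, read by MTT assay, with a stated time of 72 h (on this read-out higher numbers stand for weaker inhibition and lower numbers for stronger inhibition), compound 1 gives 96900 nM.
Compound 2 `COc1ccc(NC(=O)c2cccc(/C=C3\CC(=O)N(c4ccccc4)C3=O)c2)cc1`: in this assay compound 2 gives > 100000 nM, a limit of the assay rather than a number.
Compound 3 `COc1ccc(NC(=O)c2cccc(/C=C3\CC(=O)N(c4ccccc4)C3=O)c2)c(C)c1`: in this assay compound 3 gives > 100000 nM, again only a limit.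

Compound 3 thus stands at the limit, not at a measured number, and one of the other two values shown is a limit as well (the limit of > 100000 nM in this assay, at which 2 of the 3 values shown sit). Compound 4 `COc1ccc(OC)c(NC(=O)c2cccc(/C=C3\CC(=O)N(c4ccccc4)C3=O)c2)c1` differs from compound 3 in one place: 2,5-dimethoxyphenyl in place of 4-methoxy-2-methylphenyl on an amide-type nitrogen. For the measured compounds named here, the only measured step on this path is a step that the two limits leave unreadable from compound 2 to compound 3, and both of its ends are limits, so its size stays unreadable. No direction or size can be read for the present change, and nothing beyond the scatter is expected. Compound 4 is therefore expected to sit at the limit once more, near 120000 nM, within 50000 nM to 300000 nM. The expected step that the limit leaves unreadable from compound 3 to compound 4 carries wide uncertainty.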

Compound 4, half-maximal inhibitory concentration: > 100000 nM
Compound 4 gave a limit, no number (the forecaster's own chance of this, stated with the estimate: 70%); the middle value lies beyond the limit too.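

Compound 2, compound 3 and compound 4 each give only a limit, so no step among them can be read: the limit of > 100000 nM in this assay, at which 3 of the 4 values shown sit.

As far as these compounds go, whether changing the group on the amide-type nitrogen alters cytotoxicity in this assay stays open.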